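Swapping a tert-butyl arm for a methoxy-methyl arm

The source may hold more compounds than are shown below. What is called first, only, known or untested is meant among the compounds shown, and "the series" means these compounds.

Measured compounds:
- compound 1 `COc1cc(NC(=O)Nc2cc(Nc3cccc(C(C)(C)C)c3)ncn2)cc(OC)c1`: 35.1%
- compound 2 `COc1cc(Nc2cc(NC(=O)Nc3c(Cl)cccc3Cl)ncn2)cc(C(F)(F)F)c1`: 32.3%
- compound 3 `COc1ccc(OC)c(Nc2cc(NC(=O)Nc3c(Cl)cccc3Cl)ncn2)c1`: 93.1%

In a functional assay on NCI-H1581 cells (Homo sapiens) for inhibition, read by MTT assay, with a stated time of 48 h, tested at 10 uM (on this read-out lower numbers stand for less inhibition and higher numbers for more inhibition at the one concentration tested (going by the name of the read-out)), compound 1 gives 35.1%. Compound 2 gives 32.3%, a number so close to that of compound 1 that the two cannot be told apart. Compound 3 stands well apart with 93.1%, a gap beyond the usual scatter, so the number of compound 1 is lower than that of compound 3.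

Compound 4 `COc1cc(NC(=O)Nc2cc(Nc3ccc(OC)c(C)c3)ncn2)cc(OC)c1` has not yet been tested in this assay. It differs from compound 1 in one place: 4-methoxy-3-methylphenyl in place of 3-(tert-butyl)phenyl on a nitrogen on an aromatic ring. Among the measured compounds shown here, no measured pair shows this exact change, so the size of its effect is unknown. Compound 3 carries two methoxy groups on the ring attached to that same nitrogen and gives a higher number, but its other arm also differs, so no direct lesson can be drawn.

Compound 4 is expected to land near 42%, within 18% to 70%, which would mean an estimated step of a number 6.9 percentage points higher from compound 1 to compound 4 (within the scatter), a small upward move that may not exceed the scatter.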

Compound 4, a percentage reported as inhibition, at one concentration (the size of the read-out at that concentration, not a potency): 19.7%
Beside the measured number, compound 4's estimate is 22.3 percentage points above it, within the range that was stated.
By their numbers in this assay, from the lowest: compound 4; then compounds 2 and 1 (each within the scatter of the next); then compound 3.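

In this assay, among the compounds shown here, the exchange of 3-(tert-butyl)phenyl for 4-methoxy-3-methylphenyl on this nitrogen brings a number 15.4 percentage points lower from compound 1 to compound 4 (beyond the scatter) and gives the first reading of this position with the rest of the molecule held fixed. It shows that the aryl group here can move the number on its own, and that on the core of compound 1 this methoxy-bearing arm does not raise it. Nothing measured here gives a reason for the drop.

On these data alone, the swap removes the tert-butyl group and adds a methoxy and a methyl group all at once, so it remains open which of these changes matters. As far as these compounds go, it also remains open how this position would respond to an arm carrying an amine or a carboxylic acid, or to a plain 3-methylphenyl group.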